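Replacing the Hydroxy Amide Chain with Acetylpiperidine

This account rests on a few compounds, and the source may have more. Where it says the series, first, only, none or still open, it means among the compounds named here.

In an ADME assay on microsomes from liver (Rattus norvegicus) for metabolic stability (a lower number here means that the compound disappears faster, a higher number that the compound lasts longer), compound 3 `CC(=O)N(C)CC(O)CN1CCC(CNC(=O)c2cccc3[nH]c(C(C)C)nc23)CC1` gives > 1.5 h, which is a limit of the assay and not a number. Compound 1 `CC(=O)N1CCN(CCN2CCC(CNC(=O)c3cccc4[nH]c(C(C)C)nc34)CC2)CC1` also gives only a limit, > 1.5 h. Compound 2 `COC(=O)N(C)CC(O)CN1CCC(CNC(=O)c2cccc3[nH]c(C(C)C)nc23)CC1` gives 1.32 h. Compound 4 `CC(=O)N1CCC(CN2CCC(CNC(=O)c3cccc4[nH]c(C(C)C)nc34)CC2)CC1` differs from compound 3 as follows: 1-acetylpiperidin-4-yl in place of 2-(acetyl(methyl)amino)-1-hydroxyethyl on a saturated chain carbon bound to an amine nitrogen in a ring. Here 1-acetylpiperidin-4-yl replaces 2-(acetyl(methyl)amino)-1-hydroxyethyl on a saturated chain carbon bound to an amine nitrogen in a ring. Among the compounds with values here, three measured steps bear on this change. The floors of an at least 1.1-fold lower number from compound 1 to compound 2 (0.05 log units; that floor lies within the scatter) and an at least 1.1-fold higher number from compound 2 to compound 3 (0.05 log units; that floor lies within the scatter) lie within the scatter, while a step that the two limits leave unreadable from compound 1 to compound 3 cannot be read. The series also shows (the limit of > 1.5 h in this assay, at which 2 of the 3 values shown sit). No step beyond the scatter is expected, so the expected step is a step that the limit leaves unreadable from compound 3 to compound 4. For compound 4 the estimated half-life is 1.8 h, with an expected range of 1.1 h to 3.5 h.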

Compound 4, half-life: > 1.5 h
Compound 4 gave a limit, no number; the forecaster's own chance of this, stated with the estimate: 70%; the middle value does not contradict the limit.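

In this assay compound 4 gives only a limit of the assay, not a number. At this place, on a saturated chain carbon bound to an amine nitrogen in a ring, the 1-acetylpiperidin-4-yl group therefore reaches the same limit as groups without a ring. Within the data shown here, the one readable step is an at least 1.1-fold higher number from compound 2 to compound 4 (0.05 log units; that floor lies within the scatter), while the steps to compound 4 from compound 1 and compound 3 cannot be read. Going by these compounds, the order among compound 1, compound 3 and compound 4 stays open: the limit of > 1.5 h in this assay, at which 3 of the 4 values shown sit. Also open is how a 1-(methoxycarbonyl)piperidin-4-yl group would behave at this place.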